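Oxazoline for thiazoline on a pyrazoline sulfone

The source may report more compounds than this note shows. Statements on the series, on what has been measured and on what is new or still open speak of the compounds shown alone.

The measured compounds and their values:
Compound 1 `O=S(=O)(CC1=NCCS1)C1C(c2ccccc2)=NN(c2ccccc2)C1c1ccccc1` — "not active" (no number reported)
Compound 2 `COc1ccc(C2=NN(c3ccccc3)C(c3ccc(C)cc3)C2S(=O)(=O)CC2=NCCO2)cc1` — 67.7%
Compound 3 `COc1ccc(C2=NN(c3ccccc3)C(c3ccc(C)cc3)C2S(=O)(=O)CC2=NCCS2)cc1` — 47.9%

Three compounds sharing a pyrazoline sulfone framework were examined in a functional assay, tested at 100 ug/mL; a lower number here means a weaker effect, a higher number a stronger effect of the compound at the concentration tested. Compound 1 `O=S(=O)(CC1=NCCS1)C1C(c2ccccc2)=NN(c2ccccc2)C1c1ccccc1` is reported as "not active" (no number reported), with no number given. Compound 3 `COc1ccc(C2=NN(c3ccccc3)C(c3ccc(C)cc3)C2S(=O)(=O)CC2=NCCS2)cc1` gives 47.9% in this assay, and compound 2 `COc1ccc(C2=NN(c3ccccc3)C(c3ccc(C)cc3)C2S(=O)(=O)CC2=NCCO2)cc1` gives 67.7%. The two differ in one place: a group of 5 heavy atoms (3 carbon, 1 nitrogen, 1 oxygen; one five-membered non-aromatic ring with 2 hetero atoms) in place of a group of 5 heavy atoms (3 carbon, 1 nitrogen, 1 sulfur; one five-membered non-aromatic ring with 2 hetero atoms), on a saturated chain carbon bound to a sulfonyl sulfur. The step of a number 19.8 percentage points higher from compound 3 to compound 2 (beyond the scatter).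

Compound 4 `O=S(=O)(CC1=NCCO1)C1C(c2ccccc2)=NN(c2ccccc2)C1c1ccccc1` has not yet been measured. It stands to compound 1 as compound 2 stands to compound 3, and the change is the same one: a group of 5 heavy atoms (3 carbon, 1 nitrogen, 1 oxygen; one five-membered non-aromatic ring with 2 hetero atoms) in place of a group of 5 heavy atoms (3 carbon, 1 nitrogen, 1 sulfur; one five-membered non-aromatic ring with 2 hetero atoms), on a saturated chain carbon bound to a sulfonyl sulfur. The difference between the core of compound 1 and the core of compound 3 is not broken down here; they differ in more than one place or by a large part of the molecule.

Since the same change lifted compound 3 to compound 2 by a modest step in this assay, a similar upward step is expected from compound 1 to compound 4, though compound 1 offers no number to start from. Compound 4 is therefore expected to show only weak activity in this assay, with an estimate near 20%, ranging from 0% to 45%, and a real chance that it is again reported as not active.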

Compound 4, a percentage reported as activity, at one concentration (the size of the read-out at that concentration, not a potency): 48.1%
The estimate for compound 4 lay 28.1 percentage points below the measured number; the measured number lies above the stated range.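

In this assay, among these compounds, compound 4 gives 48.1%, while compound 1 is reported as "not active" (no number reported), so no step between these two compounds can be read. The compounds shown leave open how large the exchange of the sulfur-bearing group for the oxygen-bearing group is on the core of compound 1. No evidence is available that bears on this result.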